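Swapping the Amide Side Group on the Shared Core

This account rests on a few compounds, and the source may have more. Where it says the series, first, only, none or still open, it means among the compounds named here.

Of the compounds shown here, three sharing one core have been measured in a functional assay with Oryctolagus cuniculus as the target; a higher number here means a weaker inhibitor, a lower number a stronger inhibitor. Compound 1 `COc1ccc(-c2nc(/N=C(\N)N(C)C)sc2-c2ccc(OC)cc2)cc1` gives 37 nM. Compound 2 `COc1ccc(-c2nc(CNC(C)=O)sc2-c2ccc(OC)cc2)cc1` gives 15 nM, the lowest of the three numbers. Compound 3 `COc1ccc(-c2nc(CNC(=O)C3=NNC(=O)CC3)sc2-c2ccc(OC)cc2)cc1` gives 55 nM. Both measured steps change the group on the same aromatic carbon of the five-membered ring: a 2.5-fold lower number from compound 1 to compound 2 (0.39 log units; beyond the scatter), and a 3.7-fold higher number from compound 2 to compound 3 (0.56 log units; beyond the scatter). Each step is modest, and the position seems to tolerate different groups within a narrow band.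

Compound 4 `COc1ccc(-c2nc(C(=O)N3CCOCC3)sc2-c2ccc(OC)cc2)cc1` is not yet measured. Relative to compound 2 the change is (morpholin-4-yl)carbonyl in place of acetamidomethyl on an aromatic carbon. This removes the hydrogen-bond donor of the acetamidomethyl group and brings in a six-membered non-aromatic ring, somewhat as the ring entering in compound 3 did. Because a 3.7-fold higher number from compound 2 to compound 3 (0.56 log units; beyond the scatter) weakened inhibition when a ring was attached here, a similar modest step upward is expected, a 2.7-fold higher number from compound 2 to compound 4 (0.43 log units; beyond the scatter). Compound 4 is therefore estimated at 40 nM, within a range from 12 nM to 130 nM.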

Compound 4, half-maximal inhibitory concentration: < 10 nM
Compound 4 was reported as a limit (the forecaster's own chance of this, stated with the estimate: 3%); at least 4.0-fold (0.60 log units) between middle value and limit.
By their numbers in this assay, from the lowest: compound 2; then compounds 1 and 3 (each within the scatter of the next). At a limit, below all of these: compound 4.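

Compound 4 is reported only as a limit: the limit of < 10 nM in this assay, at which 1 of the 4 values shown sits.

Read against its neighbours, this gives an at least 3.7-fold lower number from compound 1 to compound 4 (0.56 log units; beyond the scatter), and also an at least 1.5-fold lower number from compound 2 to compound 4 (0.17 log units; that floor lies within the scatter). A six-membered non-aromatic ring on this aromatic carbon therefore does not by itself go with a higher number, as compound 3 alone had suggested, and the hydrogen-bond donor of acetamidomethyl is not required for a low number in this assay.

On these data alone, how far compound 4 lies under its limit stays unknown, so the size of its gap to compound 2 remains unsettled. Compound 4 also differs from compound 2 both in its morpholine ring and in a carbonyl set directly on the aromatic carbon, and a dimethylamino carbonyl group or a carboxylic acid at this carbon would help to separate those two changes.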